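This account rests on a few compounds, and the source may have more. Where it says the series, first, only, none or still open, it means among the compounds named here.

Compounds measured so far in a functional assay on A549 cells (Homo sapiens) for cytotoxicity, read by MTT assay, with a stated time of 48 h; on this read-out higher numbers stand for weaker inhibition and lower numbers for stronger inhibition:

Compound 1, `O=c1ccoc2cc(OCc3cn(Cc4ccc(Cl)cc4Cl)nn3)ccc12`: 5260 nM
Compound 2, `O=c1ccoc2cc(OCc3cn(Cc4ccc(F)cc4)nn3)ccc12`: a limit of the assay, > 100000 nM
Compound 3, `O=c1ccoc2cc(OCc3cn(Cc4cccc(Cl)c4)nn3)ccc12`: 13700 nM

Compound 3 stands highest of the two numbers given in this assay. Its nearest neighbour is compound 1, from which it is separated by a 2.6-fold higher number from compound 1 to compound 3 (0.42 log units; beyond the scatter). Compound 2 gives only a limit in this assay (the limit of > 100000 nM in this assay, at which 1 of the 3 values shown sits), and the gap from it to compound 3 reads an at least 7.2-fold lower number from compound 2 to compound 3 (0.86 log units; beyond the scatter). Within the data shown here, every measured step so far exchanges the whole aryl group on the saturated chain carbon bound to an aromatic nitrogen, and the sizes of those steps range from modest to large.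

Compound 4, `O=c1ccoc2cc(OCc3cn(Cc4cccc([N+](=O)[O-])c4)nn3)ccc12`, differs from compound 3 by nitro in place of chloro on an aromatic carbon. Among the measured compounds shown here, no measured step swaps a chloro for a nitro group, so the direction of the step in this assay cannot be read from the data; the measured steps show only that changes on this phenyl ring move the number by a modest to large amount. A modest step in either direction is therefore expected, a 1.5-fold higher number from compound 3 to compound 4 (0.16 log units; within the scatter). Compound 4 is expected to give 20000 nM, between 6000 nM and 70000 nM.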

Compound 4, half-maximal inhibitory concentration: 9450 nM
Compound 4: the middle estimate sits 2.1-fold (0.33 log units) above what was measured; low and high end bracket the measured number.
By their numbers in this assay, from the lowest: compounds 1, 4 and 3 (each within the scatter of the next, the first and the last beyond it). At a limit, above all of these: compound 2.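

In this assay, nitro on this aromatic carbon, which brings more heavy atoms and two hydrogen-bond acceptors, reads the same as chloro (a 1.4-fold lower number from compound 3 to compound 4 (0.16 log units; within the scatter)), so this place on the phenyl ring accepts both groups without a change beyond the scatter. The 3-nitrophenyl group also stays within the scatter of the 2,4-dichlorophenyl group (a 1.8-fold higher number from compound 1 to compound 4 (0.25 log units; within the scatter)), although the 3-chlorophenyl group does not. Compound 2 gives only a limit, so the large step to the 3-nitrophenyl group has no exact size (an at least 10-fold lower number from compound 2 to compound 4 (1.02 log units; beyond the scatter)): the limit of > 100000 nM in this assay, at which 1 of the 4 values shown sits.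

The compounds shown leave open whether an amine or a methoxy group on this aromatic carbon would also read like chloro and nitro. They also leave open whether a 4-chlorophenyl group would read like the 4-fluorophenyl group.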